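This account rests on a few compounds, and the source may have more. Where it says the series, first, only, none or still open, it means among the compounds named here.

In a functional assay on A2780 cells (Homo sapiens) for cytotoxicity, read by MTT assay, with a stated time of 24 h (a lower number here means a stronger inhibitor, a higher number a weaker inhibitor), compound 2 `COC(=O)[C@@H](CO)NC(=O)Cn1cc(C2=C(c3c[nH]c4ccccc34)C(=O)N(C)C2=O)c2ccccc21` gives 23200 nM, and compound 1 `COC(=O)[C@H](NC(=O)Cn1cc(C2=C(c3c[nH]c4ccccc34)C(=O)N(C)C2=O)c2ccccc21)C(C)C` gives 23800 nM; the step of a 1.0-fold lower number from compound 1 to compound 2 (0.01 log units; within the scatter) lies within the scatter, so neither compound stands apart. Compound 3 `COC(=O)C[C@@H](NC(=O)Cn1cc(C2=C(c3c[nH]c4ccccc34)C(=O)N(C)C2=O)c2ccccc21)C(=O)OC` differs from compound 2 by methoxycarbonyl in place of hydroxy on a saturated chain carbon, two bonds along the chain from an amide-type nitrogen and a carbonyl carbon. Within the data shown here, the one measured step swapped a side group on the saturated chain carbon bound to an amide-type nitrogen and left the number within the scatter, and the present exchange sits on that same chain. The expected step is a 1.0-fold higher number from compound 2 to compound 3 (0.01 log units; within the scatter), nothing beyond the scatter. For compound 3 the estimate is 24000 nM, with a range of 10000 nM to 55000 nM.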

Compound 3, half-maximal inhibitory concentration: 15400 nM
Estimate against measurement, compound 3: 1.6-fold (0.19 log units) above; the measured number falls inside the stated range.
By their numbers in this assay, from the lowest: compounds 3, 2 and 1 (each within the scatter of the next).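

In this assay the exchange of hydroxy for methoxycarbonyl gives a 1.5-fold lower number from compound 2 to compound 3 (0.18 log units; within the scatter), so a hydrogen-bond donor can leave this chain without a step beyond the scatter. The wider exchange of isopropyl for (methoxycarbonyl)methyl gives a 1.5-fold lower number from compound 1 to compound 3 (0.19 log units; within the scatter), so the side chains of compound 1, compound 2 and compound 3 do not separate in this assay. Nothing measured here bears on why these numbers stay together. Still open, on these data alone, is whether a side chain carrying an amine or a carboxylic acid would give a step beyond the scatter.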